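Halogen swap on the triazole aryl group across two cores

The source may report more compounds than this note shows. Statements on the series, on what has been measured and on what is new or still open speak of the compounds shown alone.

Compound 1 `CC(C)=CCC/C(C)=C/CC/C(C)=C/CC[C@@H]1[C@@]2(C)CC/C(=N\OCc3cn(-c4ccc(F)cc4)nn3)C(C)(C)[C@@H]2CC[C@@]1(C)O` and compound 2 `CC(C)=CCC/C(C)=C/CC/C(C)=C/CC[C@@H]1[C@@]2(C)CC/C(=N\OCc3cn(-c4ccc(Cl)cc4)nn3)C(C)(C)[C@@H]2CC[C@@]1(C)O` share one core; compound 3 `CC(C)=CCC/C(C)=C/CC/C(C)=C/CC[C@@H]1[C@@]2(C)C/C(=C\c3ccc(OCc4cn(-c5ccc(F)cc5)nn4)cc3)C(=O)C(C)(C)[C@@H]2CC[C@@]1(C)O` and compound 4 `CC(C)=CCC/C(C)=C/CC/C(C)=C/CC[C@@H]1[C@@]2(C)C/C(=C\c3ccc(OCc4cn(-c5ccc(Cl)cc5)nn4)cc3)C(=O)C(C)(C)[C@@H]2CC[C@@]1(C)O` share another. How the core of compound 3 differs from the core of compound 1 is not broken down here.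

In a functional assay on HeLa cells (Homo sapiens) for cytotoxicity, read by MTT assay, with a stated time of 48 h (on this read-out higher numbers stand for weaker inhibition and lower numbers for stronger inhibition), compound 1 gives 21400 nM. Compound 2 gives 14800 nM in this assay. The change between them is chloro in place of fluoro on an aromatic carbon and the measured step is a 1.4-fold lower number from compound 1 to compound 2 (0.16 log units; within the scatter). Compound 3 gives 126000 nM in this assay, the highest of the three numbers, and its gaps to compound 1 and to compound 2 are both beyond the scatter.

Compound 4 carries the same change on the second core, (chloro in place of fluoro on an aromatic carbon); the two place descriptions read the same word for word, so this is taken as the same change rather than merely the same kind. Among the measured compounds shown here, the only precedent is the step from compound 1 to compound 2, which sat within the scatter. For the measured compounds named here, on that basis the step from compound 3 to compound 4 in this assay is expected to be small as well, about a 1.3-fold lower number from compound 3 to compound 4 (0.10 log units; within the scatter), resting on the single earlier pair and on nothing else. Compound 4 is therefore estimated at 100000 nM in this assay, with a range from 50000 nM to 200000 nM.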

Compound 4, half-maximal inhibitory concentration: 50700 nM
Compound 4: the middle estimate sits 2.0-fold (0.29 log units) above what was measured, and the stated range covers the measured number.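

In this assay, chloro in place of fluoro on the core of compound 3 gives a 2.5-fold lower number from compound 3 to compound 4 (0.40 log units; beyond the scatter), a modest step, while the same change on the core of compound 1 gives a 1.4-fold lower number from compound 1 to compound 2 (0.16 log units; within the scatter). One step lies beyond the scatter and the other within it, yet the gap between them does not separate them: the same change on two cores in this assay, a 1.4-fold lower number (0.16 log units; within the scatter) from compound 1 to compound 2 and a 2.5-fold lower number (0.40 log units; beyond the scatter) from compound 3 to compound 4, 1.7-fold (0.24 log units) apart, within the scatter of two such steps The data therefore give no sign that the outcome of this change depends on the core, but with one pair per core they do not show that the step has a fixed size or that it would carry over to any further core.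

The compounds shown leave open how a bromo, a methoxy or a carboxylic acid would behave in place of the fluoro or chloro, on an aromatic carbon of the same ring, on either core. Also open is which feature of the core of compound 3 sets its numbers apart from those of the core of compound 1, since no pair shown differs between these cores in one place only.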